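A few compounds are considered here, and "the series" means these few. Any claim that something is new, unique, unknown or untested is made for them only; others in the source may bear on it.

Compound 2 `O=C(Nc1ccc(OC(F)(F)F)cc1)NC1CCN(C(=O)[C@@H]2CCOC2)CC1`: 65 ug/mL
Compound 1 `O=C(Nc1ccc(C(F)(F)F)cc1)NC1CCN(C(=O)C2=COCC2)CC1`: 8.2 ug/mL
Compound 3 `O=C(Nc1ccc(C(F)(F)F)cc1)NC1CCN(C(=O)c2ccoc2)CC1`: 6 ug/mL

These numbers come from a physicochemical assay for solubility, read by mass spectrometry, in phosphate buffer, with a stated time of 24 h, at pH 3; a lower number here means a less soluble compound, a higher number a more soluble compound. Compound 2 stands highest of the three, and its distance to compound 1 and to compound 3 lies beyond the scatter. Compound 4 `Cc1ccoc1C(=O)N1CCC(NC(=O)Nc2ccc(OC(F)(F)F)cc2)CC1` is not yet measured. It differs from compound 2 by 3-methylfuran-2-yl in place of oxolan-3-yl on a carbonyl carbon. Among the measured compounds shown here, the one measured step that bears on this is a 1.4-fold lower number from compound 1 to compound 3 (0.14 log units; within the scatter), where an aromatic five-membered ring with one oxygen replaced a non-aromatic one on the same carbonyl carbon and the number barely moved. Going by that step, and with an entering group one heavy atom larger, compound 4 is expected to sit somewhat lower, a 1.9-fold lower number from compound 2 to compound 4 (0.27 log units; within the scatter). Compound 4 is therefore estimated at 35 ug/mL, between 12 ug/mL and 90 ug/mL.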

Compound 4, solubility: 3.4 ug/mL
For compound 4 the middle estimate is 10-fold (1.01 log units) above the measured one; measured number below the stated range.
By their numbers in this assay, from the lowest: compounds 4, 3 and 1 (each within the scatter of the next, the first and the last beyond it); then compound 2.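

In this assay, the group on this carbonyl carbon is not a neutral choice: 3-methylfuran-2-yl in place of oxolan-3-yl gives a large step (a 19-fold lower number from compound 2 to compound 4 (1.28 log units; beyond the scatter)). The earlier swap of one five-membered ring for an aromatic one stayed small (a 1.4-fold lower number from compound 1 to compound 3 (0.14 log units; within the scatter)), so a small step for one ring change does not carry over to another at this place. Nothing measured here accounts for the difference.

Which part of the change matters, the aromatic ring, the added methyl or the attachment point, stays open. So does where a plain furan-2-yl or an oxolane ring carrying an amine would fall.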